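A few compounds are considered here, and "the series" means these few. Any claim that something is new, unique, unknown or untested is made for them only; others in the source may bear on it.

In a functional assay on FM3A cells (Homo sapiens) for inhibition, with FM3A (Mus musculus) as the target (on this read-out lower numbers stand for stronger inhibition and higher numbers for weaker inhibition), compound 3 `CC(=O)OC(C)n1cnc2c(Cl)nc(F)nc21` gives 93000 nM, the highest of the two numbers that are not a limit. Its nearest neighbour is compound 1 `CC(=O)OC(C)n1cnc2c(Cl)nc(I)nc21`, which gives 47000 nM, and the step of a 2.0-fold higher number from compound 1 to compound 3 (0.30 log units; within the scatter) separates them. Compound 2 `Nc1nc(I)nc2c1ncn2OCCO` gives only a limit of the assay, > 500000 nM (the limit of > 500000 nM in this assay, at which 1 of the 3 values shown sits). Compound 4 `CC(=O)OC(C)n1cnc2c(S)nc(F)nc21` is reached from compound 3 by sulfanyl in place of chloro on an aromatic carbon. For the measured compounds named here, no measured step exchanges the chloro group at this place, and the one measured step, fluoro for iodo on an aromatic carbon, stayed within the scatter, so nothing points to a shift beyond the scatter in this assay. Compound 4 is therefore expected at about 93000 nM, between 25000 nM and 350000 nM, a step of no change at the digits printed from compound 3 to compound 4 (within the scatter) that is an estimate only.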

Compound 4, half-maximal inhibitory concentration: 368000 nM
For compound 4 the middle estimate is 4.0-fold (0.60 log units) below the measured one; the measured number lies above the stated range.
By their numbers in this assay, from the lowest: compounds 1 and 3 (each within the scatter of the next); then compound 4. At a limit, above all of these: compound 2.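

In this assay, sulfanyl in place of chloro on an aromatic carbon next to the ring nitrogen brings a 4.0-fold higher number from compound 3 to compound 4 (0.60 log units; beyond the scatter), the first step beyond the scatter among these compounds. For the compounds shown here, the only earlier step changed a different place on the core, so this is the first sign that the read-out responds to a change at this position. Nothing shown accounts for this step. From the compounds shown here alone, whether a methoxy group at this position would shift the number in the same direction remains open, as does whether the step would hold with iodo in place of fluoro.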